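The compounds below may be only part of what the source reports. "The series", "measured", "known", "first", "only" and "open" are said of these compounds alone.

In a functional assay on cells (Cancer cell lines, Homo sapiens) for cytotoxicity, read by sulforhodamine B assay, with a stated time of 48 h (on this read-out higher numbers stand for weaker inhibition of growth and lower numbers for stronger inhibition of growth), compound 3 `O=C1N=C(N2N=C(c3ccccc3)CC2c2ccc(Cl)cc2)S/C1=C1/C(=O)Nc2ccccc21` gives 190 nM, the lowest of the three numbers recorded. Compound 1 `O=C1N=C(N2N=C(c3ccccc3)CC2c2ccccc2O)S/C1=C1/C(=O)Nc2ccccc21` gives 1990 nM and compound 2 `COc1ccc(C2CC(c3ccccc3)=NN2C2=NC(=O)/C(=C3\C(=O)Nc4ccccc43)S2)cc1` gives 1810 nM; the steps of a 10-fold lower number from compound 1 to compound 3 (1.02 log units; beyond the scatter) and a 9.5-fold lower number from compound 2 to compound 3 (0.98 log units; beyond the scatter) both run beyond the scatter, whereas a 1.1-fold lower number from compound 1 to compound 2 (0.04 log units; within the scatter) does not. Compound 4 `Cc1ccc2c(c1)/C(=C1\SC(N3N=C(c4ccccc4)CC3c3ccc(Cl)cc3)=NC1=O)C(=O)N2` differs from compound 3 by methyl in place of hydrogen on an aromatic carbon. For the measured compounds named here, none of the measured steps touches this part of the shared core: all three alter only the group on the saturated ring carbon. Going by the values given here, with no comparable step to draw on, the expected step in this assay is a 1.1-fold higher number from compound 3 to compound 4 (0.02 log units; within the scatter), nothing beyond the scatter. Compound 4 is therefore estimated at 200 nM, within 70 nM to 600 nM.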

Compound 4, concentration for 50% growth inhibition: 230 nM
The estimate for compound 4 lay 1.2-fold (0.06 log units) below the measured number; the range from low to high includes it.
By their numbers in this assay, from the lowest: compounds 3 and 4 (each within the scatter of the next); then compounds 2 and 1 (each within the scatter of the next).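

Methyl in place of hydrogen on this aromatic carbon gives a 1.2-fold higher number from compound 3 to compound 4 (0.08 log units; within the scatter) in this assay. For the compounds shown here, this is the first look at a change on this part of the shared core, since the earlier steps altered only the group on the saturated ring carbon, and here the added methyl leaves the number within the scatter. Nothing available explains this result.

As far as these compounds go, whether an amine, a carboxylic acid or a longer chain at this place would do the same remains open. So does whether methyl would have as little effect with the different group on the saturated ring carbon of compound 1.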